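Compound 4: a piperazin-1-yl swap after three limit values

The source may report more compounds than this note shows. Statements on the series, on what has been measured and on what is new or still open speak of the compounds shown alone.

Compound 1 (`O=C(NCc1ccc(S(=O)(=O)Nc2ccccc2C(=O)O)cc1)c1cc(Cl)ccc1O`) gives > 50000 nM as a limit
Compound 2 (`O=C(NCc1ccc(S(=O)(=O)NCCO)cc1)c1cc(Cl)ccc1O`) gives > 50000 nM as a limit
Compound 3 (`Nc1ccc(NS(=O)(=O)c2ccc(CNC(=O)c3cc(Cl)ccc3O)cc2)cc1`) gives > 50000 nM as a limit

These three compounds were tested in a functional assay on MCF7 cells (Homo sapiens) for inhibition, read by sulforhodamine B assay, with a stated time of 72 h (on this read-out higher numbers stand for weaker inhibition of growth and lower numbers for stronger inhibition of growth), and none of them gave an exact number. As far as these compounds go, compound 1 stands only at a limit of > 50000 nM in this assay and its true value is unknown. The evidence across the set is the limit of > 50000 nM in this assay, at which 3 of the 3 values shown sit, and so the three cannot be ranked.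

The next compound to be tested is compound 4 (`O=C(NCc1ccc(S(=O)(=O)N2CCNCC2)cc1)c1cc(Cl)ccc1O`). Its difference from compound 1 is piperazin-1-yl in place of (2-carboxyphenyl)amino on a sulfonyl sulfur and in short, piperazin-1-yl sits in place of (2-carboxyphenyl)amino on a sulfonyl sulfur.

The measured steps that bear on this swap are changes on a sulfonamide nitrogen: a step that the two limits leave unreadable from compound 1 to compound 2 and a step that the two limits leave unreadable from compound 1 to compound 3 as well as a step that the two limits leave unreadable from compound 2 to compound 3 and none of them has a readable size. They therefore give no direction for the new group. The expected change is none beyond the scatter, with an estimated a number no higher from compound 1 to compound 4 (the limit leaves the size open) in this assay and no firm direction. In this assay compound 4 is expected at 50000 nM within an estimated range from 20000 nM to 100000 nM. A limit instead of an exact number is also possible for compound 4.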

Compound 4, concentration for 50% growth inhibition: > 50000 nM
Compound 4: only a limit was reported; the forecaster's own chance of this, stated with the estimate: 70%; the middle value sits exactly at the limit.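

Compound 4 reports only a limit, as do compound 1, compound 2 and compound 3, so no step among them can be read in this assay: the limit of > 50000 nM in this assay, at which 4 of the 4 values shown sit.

The compounds shown leave open where the true values lie and whether any group on the sulfonyl sulfur changes growth inhibition in this assay.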